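Swapping Trifluoromethyl for Methyl on the Ester Chain

The compounds below may be only part of what the source reports. "The series", "measured", "known", "first", "only" and "open" are said of these compounds alone.

Compound 1 `CC1=C(C(=O)OC(C(F)(F)F)C(F)(F)F)C(c2ccsc2)NC(=O)N1`: 1%
Compound 2 `CC1=C(C(=O)OC(C)C(F)(F)F)C(c2cccs2)NC(=O)N1`: 1%; 4% (2 entries)

Compound 1 holds the only number shown in an assay on HEK293 cells for displacement of a labelled ligand from adenosine receptor A2b (Homo sapiens), read by radioligand binding, with a stated time of 30 min, tested at 1 uM (a lower number here means less inhibition, a higher number more inhibition at the concentration tested (going by the name of the read-out)), giving 1%; one further entry carries no single number. With the same ester chain that compound 3 will carry, compound 2 gives 1%; 4% (2 entries), and its repeated entries the several entries of compound 2 in this assay, 1%; 4% (2 entries) sit at the same low level. Compound 3 `CC1=C(C(=O)OC(C)C(F)(F)F)C(c2ccsc2)NC(=O)N1` differs from compound 1 by methyl in place of trifluoromethyl on a saturated chain carbon bound to an oxygen next to a carbonyl group and a saturated chain carbon. Among the measured compounds shown here, no measured step covers this change, so the expected step in this assay is none beyond the scatter. Compound 3 is estimated at 2%, between 0% and 12%, a step of a number 1 percentage points higher from compound 1 to compound 3 (within the scatter).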

Compound 3, a percentage reported as inhibition, at one concentration (the size of the read-out at that concentration, not a potency): 1%
Compound 3: the middle estimate sits 1 percentage points above what was measured, and the stated range covers the measured number.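

In this assay, methyl in place of trifluoromethyl on a saturated chain carbon bound to an oxygen next to a carbonyl group and a saturated chain carbon gives no change at the digits printed from compound 1 to compound 3 (within the scatter). At this position, then, neither group lifts the read-out from its low level at the concentration tested. Compound 2, which carries the same ester chain as compound 3, stays at that level too: the several entries of compound 2 in this assay, 1%; 4% (2 entries)

With every number this low, the step cannot tell whether the group at this carbon matters for inhibition at all. From the compounds shown here alone, how an amine, a carboxylic acid or a longer chain there would read remains open.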